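The source may report more compounds than this note shows. Statements on the series, on what has been measured and on what is new or still open speak of the compounds shown alone.

Measured so far in an assay on VSM-A10 cells for antagonist activity at Endothelin-1 receptor (Rattus norvegicus); on this read-out lower numbers stand for stronger inhibition and higher numbers for weaker inhibition:
- compound 1 `Cc1noc(NS(=O)(=O)c2ccc(NCc3ccccc3)cc2)c1C`: 9800 nM
- compound 2 `CCCNc1ccc(S(=O)(=O)Nc2onc(C)c2C)cc1`: 27000 nM

Compound 2 has the highest number of the two in this assay; its nearest neighbour is compound 1, and the step of a 2.8-fold higher number from compound 1 to compound 2 (0.44 log units; beyond the scatter) separates them, a modest step and beyond the scatter.

Compound 3 `Cc1noc(NS(=O)(=O)c2ccc(NC(=O)Nc3ccccc3)cc2)c1C` is not yet measured. It differs from compound 2 by phenylcarbamoyl in place of propyl on a nitrogen on an aromatic ring. For the measured compounds named here, the only step recorded that bears on this position is a 2.8-fold higher number from compound 1 to compound 2 (0.44 log units; beyond the scatter), where a phenyl on the saturated chain carbon at this nitrogen went with the lower number. Going by the values given here, the present change again brings in a phenyl ring at the same nitrogen, though now through a carbamoyl linker rather than a methylene, so no direct precedent exists for the linker itself.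

On that basis a modest move toward a lower number is expected for compound 3, of about the size a 2.3-fold lower number from compound 2 to compound 3 (0.35 log units; beyond the scatter), with wide uncertainty because only a 2.8-fold higher number from compound 1 to compound 2 (0.44 log units; beyond the scatter) supports it. Compound 3 is estimated at 12000 nM in this assay, within the range 3000 nM to 50000 nM.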

Compound 3, half-maximal inhibitory concentration: 38000 nM
Beside the measured number, compound 3's estimate is 3.2-fold (0.50 log units) below it, within the range that was stated.
By their numbers in this assay, from the lowest: compound 1; then compounds 2 and 3 (each within the scatter of the next).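

In this assay the phenyl ring alone does not go with the lower number seen for the benzyl group of compound 1: replacing benzyl with phenylcarbamoyl on the nitrogen on an aromatic ring gives a step beyond the scatter (a 3.9-fold higher number from compound 1 to compound 3 (0.59 log units; beyond the scatter)). Phenylcarbamoyl, with 9 heavy atoms, 1 hydrogen-bond donor and 1 hydrogen-bond acceptor, is not told apart in this read-out from propyl, with 3 heavy atoms and neither donor nor acceptor (a 1.4-fold higher number from compound 2 to compound 3 (0.15 log units; within the scatter)), so among these three groups only benzyl stands apart, and only by a modest margin. No measurement at hand offers a reason for either step.

From the compounds shown here alone, whether the lower number of compound 1 depends on the single saturated carbon linking the phenyl ring to this nitrogen, or would persist with a longer chain such as 2-phenylethyl, remains open. Also open, going by these compounds, is how a free amine, an acetyl group or a chloro substituent on the benzyl ring would compare at this position.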